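This account rests on a few compounds, and the source may have more. Where it says the series, first, only, none or still open, it means among the compounds named here.

In an ADME assay on MT4 cells (Homo sapiens) for cytotoxicity, read by MTT assay, with a stated time of 5 days (a higher number here means that more compound is tolerated, a lower number that less compound is tolerated), compound 1 `N#Cc1ccc(Nc2nccc([C@@H](O)c3ccc(-c4ccc(C#N)cc4)cc3Cl)n2)cc1` gives 4250 nM, while compound 2 `N#Cc1ccc(Nc2nccc([C@H](O)c3ccc(-c4ccc(C#N)cc4)cc3F)n2)cc1` gives 30000 nM, the higher of the two numbers and a gap beyond the scatter of repeated measurements. The next molecule, compound 3 `N#Cc1ccc(Nc2nccc([C@@H](O)c3ccc(-c4ccc(C#N)cc4)cc3F)n2)cc1`, is compared with compound 2: the two compounds have the same atoms and bonds and differ only in configuration as drawn: 1 of 1 stereo elements differ; a stereocentre at a saturated chain carbon is drawn R in compound 2 and S in compound 3. The two compounds have the same atoms and bonds and differ only in configuration as drawn: a stereocentre at a saturated chain carbon is drawn R in compound 2 and S in compound 3. Within the data shown here, no pair of measured compounds shows what such a change does in this assay, so the guide is weak. A modest fall is expected, as compound 2 holds the top number and compound 1 stands lower at 4250 nM. The expected change is a 2.0-fold lower number from compound 2 to compound 3 (0.30 log units; within the scatter). For compound 3 the estimated value is 15000 nM, with an expected range from 5000 nM to 40000 nM.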

Compound 3, half-maximal cytotoxic concentration: 7500 nM
For compound 3 the middle estimate is 2.0-fold (0.30 log units) above the measured one, and the stated range covers the measured number.
By their numbers in this assay, from the lowest: compounds 1 and 3 (each within the scatter of the next); then compound 2.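

In this assay, a change at a single stereocentre, from R to S at a saturated chain carbon, gives a 4.0-fold lower number from compound 2 to compound 3 (0.60 log units; beyond the scatter), a first sign that the arrangement in space at this carbon matters for how much compound the cells tolerate. The gap can be assigned to that configuration alone, because nothing else separates the pair: the fact that compounds 2 and 3 differ only in the configuration as drawn. By contrast, fluoro in place of chloro on an aromatic carbon gives a 1.8-fold higher number from compound 1 to compound 3 (0.25 log units; within the scatter), so this swap shows no clear change.

Only one pair differing in configuration is shown, so it remains open whether the same change would have a similar effect in a chloro compound. Also open, as far as these compounds go, is what bromo or methyl in place of fluoro on that aromatic carbon would do.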